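Same aryl swap on two cores, one step measured

The compounds below may be only part of what the source reports. "The series", "measured", "known", "first", "only" and "open" are said of these compounds alone.

Compound 1 `COc1ccc(NC(=O)Nc2nc(Sc3c[nH]c4ccccc34)cc(N3CCCCC3)n2)cc1` gives 17400 nM in a functional assay on PC-3 cells (Homo sapiens) for inhibition, with a stated time of 72 h; on this read-out higher numbers stand for weaker inhibition and lower numbers for stronger inhibition.
Compound 2 `Cc1ccc(C)c(NC(=O)Nc2nc(Sc3c[nH]c4ccccc34)cc(N3CCCCC3)n2)c1` is reported only as a limit in this assay, > 50000 nM.
Compound 3 `Cc1ccc(C)c(NC(=O)Nc2nc(Sc3c[nH]c4ccccc34)cc(N3CCN(Cc4ccccc4)CC3)n2)c1` gives 17300 nM in this assay.

Compound 2 and compound 1 differ in one place only, by 4-methoxyphenyl in place of 2,5-dimethylphenyl on an amide-type nitrogen. That change produced an at least 2.8-fold lower number from compound 2 to compound 1 (0.45 log units; beyond the scatter). Its true size is open at the top, since the number for compound 2 is only a limit, (the limit of > 50000 nM in this assay, at which 1 of the 3 values shown sits). Compound 3 carries a different core from compound 2; the difference between the two cores is not broken down here. In this assay, compound 3 and compound 1 give numbers that lie within the usual scatter of each other, so no order between them can be read.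

Compound 4 `COc1ccc(NC(=O)Nc2nc(Sc3c[nH]c4ccccc34)cc(N3CCN(Cc4ccccc4)CC3)n2)cc1` has not been measured. Going by the values given here, it differs from compound 3 by 4-methoxyphenyl in place of 2,5-dimethylphenyl on an amide-type nitrogen, which is the same change, at the same place, as the one from compound 2 to compound 1. Because that change gave an at least 2.8-fold lower number from compound 2 to compound 1 (0.45 log units; beyond the scatter) on the other core, a step of the same direction is expected here, though the measured step is only a lower bound and the core is not the same, which leaves the size uncertain. The step from compound 3 to compound 4 is therefore expected to be a 2.5-fold lower number from compound 3 to compound 4 (0.39 log units; beyond the scatter). Compound 4 is expected to give about 7000 nM in this assay, most likely between 2500 nM and 25000 nM.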

Compound 4, half-maximal inhibitory concentration: 16700 nM
For compound 4 the middle estimate is 2.4-fold (0.38 log units) below the measured one, within the range that was stated.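

On the core shared by the newly measured pair, putting 4-methoxyphenyl in place of 2,5-dimethylphenyl on the amide-type nitrogen gave a 1.0-fold lower number from compound 3 to compound 4 (0.02 log units; within the scatter) in this assay, so no effect of the change can be read on this core. Set beside the earlier result, the step did not keep its size when the change moved from one core to the other: the same change on two cores in this assay, an at least 2.8-fold lower number (0.45 log units; beyond the scatter) from compound 2 to compound 1 and a 1.0-fold lower number (0.02 log units; within the scatter) from compound 3 to compound 4, at least 2.7-fold (0.44 log units) apart, beyond the scatter of two such steps. Going by these compounds alone, this shows that, in this series, a step measured on one core was a poor guide to the same change on the other, but with only one pair on each core it does not show why the two steps differ or what the change would do on any further core.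

Compound 2 is reported only as a limit, > 50000 nM, which leaves the true size of the step on the first core open. Also open, on these data alone, is whether other groups on the amide-type nitrogen, such as an unsubstituted phenyl ring, a phenyl ring carrying a carboxylic acid or an amine, or a longer chain in place of the ring, would give steps that differ between the two cores.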